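The source may hold more compounds than are shown below. What is called first, only, known or untested is meant among the compounds shown, and "the series" means these compounds.

Compound 1 `COc1cc(-c2nn(-c3cccc(NC(=O)Nc4cc(C(F)(F)F)cc(C(F)(F)F)c4)c3)cc2-c2ccncc2)ccc1Cl` gives 892 nM in a functional assay on Malme-3M cells (Homo sapiens) for inhibition, read by sulforhodamine B assay, with a stated time of 48 h; on this read-out higher numbers stand for weaker inhibition of growth and lower numbers for stronger inhibition of growth.
Compound 2 `COc1cc(-c2nn(-c3cccc(NC(=O)c4cccc(C(F)(F)F)c4)c3)cc2-c2ccncc2)ccc1Cl` gives 1990 nM in this assay.
Compound 3 `O=C(Nc1cccc(-n2cc(-c3ccncc3)c(-c3ccc(Cl)c(O)c3)n2)c1)Nc1cc(C(F)(F)F)cc(C(F)(F)F)c1` gives 939 nM in this assay.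

Compound 2 stands at the highest number of the three, beyond the scatter from both compound 3 and compound 1, so it is the weakest inhibitor of growth among the compounds measured here. Compound 4 `COc1cc(-c2nn(-c3cccc(NC(=O)Nc4ccc(Cl)c(C(F)(F)F)c4)c3)cc2-c2ccncc2)ccc1Cl` has not yet been measured. It differs from compound 2 in one place: (4-chloro-3-(trifluoromethyl)phenyl)amino in place of 3-(trifluoromethyl)phenyl on a carbonyl carbon. For the measured compounds named here, the only step measured so far, a 1.1-fold higher number from compound 1 to compound 3 (0.02 log units; within the scatter), concerns a different part of the molecule and says nothing about this change. Compound 1 carries an amino-linked aryl on the carbonyl carbon, as compound 4 does, though with other substituents on that ring; its number and that of compound 2 lie more than the scatter apart, with compound 1 lower. On that basis the change is expected to lower the number, by a step of about a 2.3-fold lower number from compound 2 to compound 4 (0.37 log units; beyond the scatter). Compound 4 is therefore estimated to give 850 nM in this assay, with a range from 350 nM to 2000 nM.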

Compound 4, concentration for 50% growth inhibition: 838 nM
For compound 4 the middle estimate is 1.0-fold (0.01 log units) above the measured one; measured number inside the range.
By their numbers in this assay, from the lowest: compounds 4, 1 and 3 (each within the scatter of the next); then compound 2.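

In this assay the exchange on the carbonyl carbon can now be read directly, as a 2.4-fold lower number from compound 2 to compound 4 (0.38 log units; beyond the scatter). For the compounds shown here, this is the first step measured at this place: the earlier step, a 1.1-fold higher number from compound 1 to compound 3 (0.02 log units; within the scatter), concerned the methyl on an oxygen on an aromatic ring, and compound 1 and compound 2 differ in more than one place. The step belongs to the whole exchange, in which the entering group brings a nitrogen with its hydrogen-bond donor and a chlorine together, and nothing measured on these compounds explains why the number falls.

The compounds shown leave open how much of the step comes from the amino nitrogen and how much from the chlorine, a question that (3-(trifluoromethyl)phenyl)amino on the same carbonyl carbon would separate by carrying the nitrogen without the chlorine. They also leave open whether the same exchange would give a similar step with the hydroxyl group of compound 3 in place of the methoxy group, and whether a morpholine on this carbonyl carbon would be tolerated at all.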